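The source may hold more compounds than are shown below. What is called first, only, known or untested is meant among the compounds shown, and "the series" means these compounds.

Measured compounds in a functional assay on SGC-7901 cells (Homo sapiens) for antiproliferative activity, read by sulforhodamine B assay, with a stated time of 72 h (on this read-out higher numbers stand for weaker inhibition and lower numbers for stronger inhibition), so far:
compound 1 `COc1ccccc1NC(=S)N/N=C/c1ccc2ccccc2n1` gives > 100000 nM (a limit of the assay, not a number)
compound 2 `S=C(NCc1ccccc1)N/N=C/c1ccc2ccccc2n1` gives 53700 nM
compound 3 `NC(=S)N/N=C/c1ccc2ccccc2n1` gives 32700 nM

Compound 3, with hydrogen on the amide-type nitrogen, cannot be separated from compound 2, as the measured step shows (a 1.6-fold lower number from compound 2 to compound 3 (0.22 log units; within the scatter)). It does stand apart from compound 1 (an at least 3.0-fold lower number from compound 1 to compound 3 (0.48 log units; beyond the scatter)).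

The next step leads to compound 4 `Cc1ccc(NC(=S)N/N=C/c2ccc3ccccc3n2)cc1` and puts 4-methylphenyl in place of that hydrogen (4-methylphenyl in place of hydrogen on an amide-type nitrogen). Going by the values given here, the nearest precedent is compound 1, which carries 2-methoxyphenyl on the same nitrogen. Read in reverse, its step to compound 3 (an at least 3.0-fold lower number from compound 1 to compound 3 (0.48 log units; beyond the scatter)) suggests that an aromatic ring at this place raises the number. The benzyl comparison is weaker support, since its step to hydrogen (a 1.6-fold lower number from compound 2 to compound 3 (0.22 log units; within the scatter)) stays within the scatter. The floor of the step between the two substituted compounds (an at least 1.8-fold lower number from compound 1 to compound 2 (0.27 log units; that floor lies within the scatter)) also stays within the scatter. The evidence is a single limit-bound step, so the direction is expected only tentatively, and the size is poorly fixed.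

A modest rise is expected, and the estimated step is a 1.8-fold higher number from compound 3 to compound 4 (0.26 log units; within the scatter) in this direction. A limit rather than a number is also possible for compound 4. In this assay the expected value for compound 4 is 60000 nM with an estimated range of 18000 nM to 100000 nM.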

Compound 4, half-maximal inhibitory concentration: 92900 nM
Beside the measured number, compound 4's estimate is 1.5-fold (0.19 log units) below it; low and high end bracket the measured number.
By their numbers in this assay, from the lowest: compounds 3, 2 and 4 (each within the scatter of the next, the first and the last beyond it). At a limit, above all of these: compound 1.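

In this assay, 4-methylphenyl in place of hydrogen on the amide-type nitrogen gives the first step from hydrogen to an aromatic ring that has a number at both ends (a 2.8-fold higher number from compound 3 to compound 4 (0.45 log units; beyond the scatter)). This step lies beyond the scatter, so a rise that earlier rested only on a limit-bound step now has a size, though a modest one. Against benzyl the same group cannot be separated (a 1.7-fold higher number from compound 2 to compound 4 (0.24 log units; within the scatter)), so the rise is shown only against hydrogen and not for every larger group on this nitrogen. Against 2-methoxyphenyl only a floor can be given, and that floor lies within the scatter (an at least 1.0-fold lower number from compound 1 to compound 4 (0.03 log units; that floor lies within the scatter)). Compound 1 stands at a limit, not a number: the limit of > 100000 nM in this assay, at which 1 of the 4 values shown sits.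

Going by these compounds, it remains open whether a short chain such as methyl or ethyl on the amide-type nitrogen would fall with hydrogen or with the aromatic groups. It also remains open whether an amine or a carboxylic acid on the aromatic ring would move the number in either direction, since the only substituents shown on that ring are methyl and methoxy.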